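Methoxy on the Phenyl Ring: An Expected Small Step

The source may report more compounds than this note shows. Statements on the series, on what has been measured and on what is new or still open speak of the compounds shown alone.

Measured so far:
compound 1, `Brc1cn2ccnc2c(-c2ccc3ncn(C4CCCCC4)c3c2)n1`: 16.2%
compound 2, `c1ccc(-c2cn3ccnc3c(-c3ccc4ncn(C5CCCCC5)c4c3)n2)cc1`: 58.1%

In a functional assay on NCI-H522 cells (Homo sapiens) for inhibition, read by sulforhodamine B assay, with a stated time of 48 h, tested at 10 uM (on this read-out lower numbers stand for less inhibition and higher numbers for more inhibition at the one concentration tested (going by the name of the read-out)), compound 2 gives the higher of the two numbers; compound 1 lies well below it, and the step of a number 41.9 percentage points higher from compound 1 to compound 2 (beyond the scatter) is beyond the scatter. Compound 3, `COc1ccc(-c2cn3ccnc3c(-c3ccc4ncn(C5CCCCC5)c4c3)n2)cc1`, has not been measured. It differs from compound 2 by methoxy in place of hydrogen on an aromatic carbon, placed on an aromatic carbon of a six-membered aromatic ring of carbon only. Among the compounds with values here, the only measured step swaps bromo for phenyl, a different kind of change, so nothing measured here speaks directly to adding a methoxy group. For that reason compound 3 is expected to stay near compound 2, with a step of a number 3.1 percentage points lower from compound 2 to compound 3 (within the scatter) that is estimated to lie within the scatter. The estimate for compound 3 is 55%, ranging from 35% to 75%.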

Compound 3, a percentage reported as inhibition, at one concentration (the size of the read-out at that concentration, not a potency): -20.9%
Beside the measured number, compound 3's estimate is 75.9 percentage points above it; measured number outside the range, below it.
By their numbers in this assay, from the lowest: compound 3; then compound 1; then compound 2.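

In this assay, the phenyl ring of compound 2 proves far from indifferent to what it carries: methoxy on the carbon para to a large group, only 2 heavy atoms in place of a hydrogen, gives a large fall (the step is a number 79 percentage points lower from compound 2 to compound 3 (beyond the scatter) in this comparison). The gain from replacing bromo with phenyl therefore does not carry over to 4-methoxyphenyl, which instead falls short of bromo (the step is a number 37.1 percentage points lower from compound 1 to compound 3 (beyond the scatter) here). Compound 3 also gives a negative number (-20.9%), so no inhibition shows in this read-out at the one concentration tested. Nothing available explains this fall.

On these data alone, whether it belongs to methoxy alone or to any group on this carbon stays open: only hydrogen and methoxy can be compared here. Fluoro, hydroxy or an amine on the same carbon would help separate these readings.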